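The source may report more compounds than this note shows. Statements on the series, on what has been measured and on what is new or still open speak of the compounds shown alone.

Series notes. Among the measured compounds shown here, the two compounds measured so far share one core and differ only in the aryl group on the ring nitrogen. Compound 1 `CCOc1ccccc1Nc1nc(SCc2ccc(C(F)(F)F)cc2)nc2ccccc12` carries a 2-ethoxyphenyl there; in a functional assay on PC-3 cells (Homo sapiens) for cytotoxicity, read by MTT assay, with a stated time of 72 h (a higher number here means a weaker inhibitor, a lower number a stronger inhibitor), compound 1 gives 26200 nM. Compound 2 `Cc1ccc(Nc2nc(SCc3ccc(C(F)(F)F)cc3)nc3ccccc23)cc1` carries a 4-methylphenyl instead; in this assay compound 2 gives 21100 nM. For the measured compounds named here, the one step available, a 1.2-fold lower number from compound 1 to compound 2 (0.09 log units; within the scatter), shows that exchanging the aryl group left the read-out essentially where it was. Compound 2 thus holds the lower of the two numbers, but only by a margin that means nothing on its own.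

Compound 3 `COc1cc(Nc2nc(SCc3ccc(C(F)(F)F)cc3)nc3ccccc23)cc(OC)c1` is the next member, not yet measured. Its change from compound 2 is 3,5-dimethoxyphenyl in place of 4-methylphenyl on a nitrogen on an aromatic ring. Going by the values given here, no measured step touches a dimethoxyphenyl, so the only guide is the step from compound 1 to compound 2, which was within the scatter for a comparable exchange of the aryl group. On that basis the step of a 1.0-fold higher number from compound 2 to compound 3 (0.02 log units; within the scatter) is expected to stay within the scatter as well, with no clear direction. Compound 3 is therefore estimated to give 22000 nM in this assay, with a likely range from 8000 nM to 60000 nM.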

Compound 3, half-maximal inhibitory concentration: > 50000 nM
Compound 3 was reported as a limit; the forecaster's own chance of this, stated with the estimate: 15%; middle value at least 2.2-fold (0.35 log units) from the limit.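

In this assay compound 3 is reported only as a limit of the assay, not as a number: the limit of > 50000 nM in this assay, at which 1 of the 3 values shown sits. Among the compounds shown here, the change to 3,5-dimethoxyphenyl on this nitrogen gives an at least 2.3-fold higher number from compound 2 to compound 3 (0.37 log units; beyond the scatter), the first step at this position to leave the scatter, so the aryl group here can no longer be treated as freely interchangeable, as a 1.2-fold lower number from compound 1 to compound 2 (0.09 log units; within the scatter) alone might have suggested. Measured from the 2-ethoxyphenyl member, the same group gives an at least 1.9-fold higher number from compound 1 to compound 3 (0.28 log units; that floor lies within the scatter), so that comparison on its own does not separate the two, and the shift is established only against the 4-methylphenyl member.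

The compounds shown do not tell whether the loss belongs to having two methoxy groups, to where they stand on the phenyl ring, or to the larger group as a whole, and they give no reading for a single methoxy group, an amine or a carboxylic acid on that ring. As far as these compounds go, how far compound 3 lies past its limit also remains open, and with it the true size of both new steps.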